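A few compounds are considered here, and "the series" means these few. Any claim that something is new, unique, unknown or untested is made for them only; others in the source may bear on it.

Compound 1 `CC/N=C(\S)NCCCCCn1nc(-c2ccccc2)ccc1=O`: 66.4%
Compound 2 `CC/N=C(/NC#N)NCCCCCCn1nc(-c2ccccc2)ccc1=O`: 29.1%
Compound 3 `CC/N=C(/NC#N)NCCCCCn1nc(-c2ccccc2)ccc1=O`: 48.2%

In a functional assay on the whole organism with Rattus norvegicus as the target, at a dose of 100 mg/kg (a lower number here means less inhibition, a higher number more inhibition at the dose given (going by the name of the read-out)), compound 3 stands second highest of the three numbers shown. Its nearest neighbour is compound 1: the step of a number 18.2 percentage points lower from compound 1 to compound 3 (beyond the scatter) is beyond the scatter but modest. Compound 2 lies furthest away: the step of a number 19.1 percentage points higher from compound 2 to compound 3 (beyond the scatter) is also modest, so compound 3 sits about midway between the other two. The largest step shown, a number 37.3 percentage points lower from compound 1 to compound 2 (beyond the scatter), combines the two smaller changes.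

Compound 4 `CN(C)/C(=N/CCCCCn1nc(-c2ccccc2)ccc1=O)NC#N` has not yet been measured in this assay. Compared with compound 3 it holds the same atoms joined differently: a group of 8 heavy atoms (4 carbon, 4 nitrogen; no ring) in place of a group of 8 heavy atoms (4 carbon, 4 nitrogen; no ring), on a saturated chain carbon, five bonds along the chain from an aromatic nitrogen. The group that leaves carries two hydrogen-bond donors, the group that enters only one.

For the measured compounds named here, none of the measured steps makes this exact change, so no step bears on it directly. What the steps do show is that changes at this position, five bonds along the chain from the aromatic nitrogen, shifted the number by modest to large amounts. A rearrangement without gain or loss of atoms is expected to move the number less than that: the step of a number 8.2 percentage points lower from compound 3 to compound 4 (within the scatter) is estimated to lie near or just beyond the scatter, downward. Compound 4 is therefore expected to give 40%, within 22% to 58%.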

Compound 4, a percentage reported as inhibition, in the whole organism at one dose (the size of the read-out at that dose, not a potency): 63.9%
The estimate for compound 4 lay 23.9 percentage points below the measured number, outside the stated range (above it).
By their numbers in this assay, from the lowest: compound 2; then compound 3; then compounds 4 and 1 (each within the scatter of the next).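

In this assay, rearranging the same atoms, so that the entering group carries one hydrogen-bond donor where the leaving group carried two, gave a number 15.7 percentage points higher from compound 3 to compound 4 (beyond the scatter); at this place on the chain, how the atoms are joined matters, not only which atoms are present. The rearranged group also stands well clear of the larger group in compound 2, with a number 34.8 percentage points higher from compound 2 to compound 4 (beyond the scatter), while no difference can be claimed from the sulfur-containing group of compound 1, with a number 2.5 percentage points lower from compound 1 to compound 4 (within the scatter). Nothing available explains why the rearrangement changes the read-out in this whole-animal test.

Compound 4 differs from compound 3 both in its donor count and in having two methyl groups on one nitrogen, so these compounds cannot show which of the two goes with the higher number. On these data alone, it also remains open whether a diethylamino group or a pyrrolidine ring on that nitrogen would give a similar number, and whether the rearranged group would behave the same way on the longer chain of compound 2.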